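Enlarging the Amide Group of Compound 2

The compounds below may be only part of what the source reports. "The series", "measured", "known", "first", "only" and "open" are said of these compounds alone.

Measured so far:
compound 1, `Cc1ccc(Cn2c(CN3CCN(C(=O)C4CC4)CC3)nc3ccccc32)cc1`, 51.5%
compound 2, `CC(=O)N1CCN(Cc2nc3ccccc3n2Cc2cccc(C)c2)CC1`, 70.3%
compound 3, `O=C(C1CC1)N1CCN(Cc2nc3ccccc3n2Cc2ccc(F)cc2)CC1`, 32.7%

In an assay on isolated protein for inhibition of aldehyde dehydrogenase 1A1 (Homo sapiens), read by spectrophotometry, tested at 10 uM (a lower number here means less inhibition, a higher number more inhibition at the concentration tested (going by the name of the read-out)), compound 2 stands highest of the three numbers; compound 1 with 51.5% and compound 3 with 32.7% both lie beyond the scatter below it. For the measured compounds named here, the only step measured between compounds that differ in one place, a number 18.8 percentage points lower from compound 1 to compound 3 (beyond the scatter), concerns an aromatic carbon rather than the carbonyl carbon, so it bears little on the change considered here. Compound 4, `COc1ccc(C(=O)N2CCN(Cc3nc4ccccc4n3Cc3cccc(C)c3)CC2)cc1`, differs from compound 2 by 4-methoxyphenyl in place of methyl on a carbonyl carbon. Going by the values given here, compound 1 and compound 2 also differ on the carbonyl carbon, yet they differ elsewhere too, so their gap cannot be read as a single step; the data hold no clean precedent for replacing methyl on this carbonyl with a larger group of eight heavy atoms. A modest downward step, a number 15.3 percentage points lower from compound 2 to compound 4 (beyond the scatter), is expected, with wide uncertainty. Compound 4 is therefore estimated at 55%, within 30% to 80%.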

Compound 4, a percentage reported as inhibition, at one concentration (the size of the read-out at that concentration, not a potency): 55.5%
The estimate for compound 4 lay 0.5 percentage points below the measured number; the measured number falls inside the stated range.
By their numbers in this assay, from the lowest: compound 3; then compounds 1 and 4 (each within the scatter of the next); then compound 2.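

In this assay, the carbonyl carbon of compound 2 now has its first measured single-place change, which reads a number 14.8 percentage points lower from compound 2 to compound 4 (beyond the scatter). Replacing methyl with 4-methoxyphenyl, a group of eight heavy atoms with one six-membered aromatic ring, lowers the number but does not remove inhibition at the concentration tested, and compound 4 still gives 55.5%. Nothing available explains this step.

The compounds shown leave open whether the aromatic ring or its methoxy group accounts for the step, a question that plain phenyl on the same carbonyl carbon would help to settle. Going by these compounds, it also remains open how this number would respond to an amine or a carboxylic acid in place of the methoxy group.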